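Swapping the aryl arm on a thiazole acetic acid scaffold

This account rests on a few compounds, and the source may have more. Where it says the series, first, only, none or still open, it means among the compounds named here.

Measured compounds:
Compound 1 `Nc1nc(-c2ccc(Cl)cc2)c(CC(=O)O)s1` gives > 100000 nM in an in vitro functional assay on HEK285-7 cells for antagonist activity at prostaglandin D2 receptor 2 (Homo sapiens), read by BRET and beta-arrestin recruitment (a lower number here means a stronger inhibitor, a higher number a weaker inhibitor), which is a limit of the assay and not a number.
Compound 2 `O=C(O)Cc1sc(C(c2ccccc2)c2ccccc2)nc1-c1ccc(F)cc1` gives 77 nM.
Compound 3 `O=C(O)Cc1sc(C(c2ccc(F)cc2)c2ccc(F)cc2)nc1-c1ccoc1` gives 130 nM.

Compound 3 holds the higher of the two numbers available, and its nearest neighbour, compound 2, sits within the scatter of it, so the two cannot be ranked. Compound 1 sits at a limit of > 100000 nM in this assay, at which 1 of the 3 values shown sits, and gives no number to compare.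

Compound 4 `CN(C)c1cc(-c2nc(C(c3ccc(F)cc3)c3ccc(F)cc3)sc2CC(=O)O)ccn1` differs from compound 3 in one place: 2-(dimethylamino)pyridin-4-yl in place of furan-3-yl on an aromatic carbon. Among the measured compounds shown here, no step between measured compounds mirrors this change. With the aryl group on that carbon already tolerating both a substituted phenyl and a furan, the step is expected to be small and not beyond the scatter. The step of a 1.6-fold lower number from compound 3 to compound 4 (0.21 log units; within the scatter) is the expectation here. Compound 4 is therefore estimated at 80 nM, from 25 nM to 250 nM.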

Compound 4, half-maximal inhibitory concentration: > 100000 nM
Compound 4 was reported as a limit (the forecaster's own chance of this, stated with the estimate: 5%); middle value at least 1200-fold (3.09 log units) away from the limit.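

On this carbon next to the ring nitrogen, putting 2-(dimethylamino)pyridin-4-yl in place of furan-3-yl gives an at least 760-fold higher number from compound 3 to compound 4 (2.88 log units; beyond the scatter). This position therefore does not accept every aromatic group, and a single swap here can take a compound from a measurable value to none. Compound 4 is reported only as a limit of the assay, not a number: the limit of > 100000 nM in this assay, at which 2 of the 4 values shown sit.

From the compounds shown here alone, whether a plain pyridin-4-yl ring, without the dimethylamino group, would keep the activity of compound 3 remains open. So does whether a dimethylamino group on a phenyl ring would lose it.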